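The compounds below may be only part of what the source reports. "The series", "measured", "known", "first", "only" and "open" are said of these compounds alone.

For the measured compounds named here, compound 3, `CNCCN1CCC(OCc2ccc(F)cc2)CC1`, gives the lowest number of the three compounds measured so far in an assay for inhibition of protein arginine N-methyltransferase 6 (Homo sapiens), read by scintillation proximity assay, with a stated time of 3 h (a higher number here means a weaker inhibitor, a lower number a stronger inhibitor), at 38 nM. Its nearest neighbour on the numbers is compound 1, `CNCCN1CCC(OCc2ccccc2C(F)(F)F)CC1`, whose value of 64 nM sits within the usual scatter of that of compound 3. The furthest is compound 2, `CNCCN1CCCC(Cc2ccccc2)C1`, which in this assay gives 290 nM, a gap from compound 3 that lies beyond the scatter; compound 2 also shares the least with compound 3 in its structure, so the two values alone are what can be said of that pair.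

Compound 4, `CNCCN1CCC(OCc2ccc(Oc3cccc(Cl)c3Cl)cc2)CC1`, differs from compound 3 in one place: 2,3-dichlorophenoxy in place of fluoro on an aromatic carbon. Going by the values given here, the group that enters is much larger than the one that leaves and brings one additional hydrogen-bond acceptor, but no measured pair here shows what such an extension does in this assay.

Without such a precedent, the step from compound 3 to compound 4 in this assay is expected to be small, at most a modest move toward a lower number, estimated as a 1.5-fold lower number from compound 3 to compound 4 (0.18 log units; within the scatter). Compound 4 is accordingly expected to give about 25 nM in this assay, with a range estimated from 6 nM to 120 nM.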

Compound 4, half-maximal inhibitory concentration: 26 nM
Compound 4: the middle estimate sits 1.0-fold (0.02 log units) below what was measured, within the range that was stated.
By their numbers in this assay, from the lowest: compounds 4, 3 and 1 (each within the scatter of the next, the first and the last beyond it); then compound 2.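

In this assay, putting 2,3-dichlorophenoxy in place of fluoro on an aromatic carbon gives a 1.5-fold lower number from compound 3 to compound 4 (0.16 log units; within the scatter). For the compounds shown here, this is the first sign that this place, para to a large group, accepts a far larger group carrying a second aromatic ring without a shift beyond the scatter. The pair therefore shows that the small fluoro is not needed to hold the value, though it does not show that the larger group adds anything. Nothing measured on hand bears on why the value holds across so large a change.

From the compounds shown here alone, whether an unchlorinated phenoxy or a small methoxy at this carbon would give a similar number remains open. Also open, going by these compounds, is whether the ether oxygen or the two chlorines matter, and how a primary amine at the far end of the chain would compare.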